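The source may report more compounds than this note shows. Statements on the series, on what has been measured and on what is new or still open speak of the compounds shown alone.

Compound 1, `C=C[C@@](C)(/C=C/c1ccc(Nc2ccc(OC)cc2)cc1)CCC=C(C)C`, was tested in a functional assay on SEM cells (Homo sapiens) for cytotoxicity, with a stated time of 72 h; a lower number here means that less compound is needed, a higher number that more compound is needed for the effect. In this assay compound 1 gives > 36600 nM, which is a limit of the assay and not a number. Compound 2, `C=C[C@@](C)(/C=C/c1ccc(Nc2ccc(OC)c(OC)c2)cc1)CCC=C(C)C`, carries methoxy in place of hydrogen on an aromatic carbon. In this assay compound 2 gives > 36600 nM, again a limit. The step that the two limits leave unreadable from compound 1 to compound 2 therefore cannot be read, and the limit of > 36600 nM in this assay, at which 2 of the 2 values shown sit, sums up where both values sit. Compound 3, `C=C[C@@](C)(/C=C/c1ccc(-c2cccc(Br)c2)cc1)CCC=C(C)C`, differs from compound 1 by 3-bromophenyl in place of (4-methoxyphenyl)amino on an aromatic carbon. For the measured compounds named here, the only measured step is hidden behind two limits, and no measured step bears on this change. With both known values at the limit, the expectation for compound 3 in this assay is a step that the limit leaves unreadable from compound 1 to compound 3 that most likely leaves it at the limit as well. Compound 3 is therefore estimated at 40000 nM, with a range from 8000 nM to 150000 nM.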

Compound 3, half-maximal effective concentration: > 36600 nM
Compound 3 gave a limit, no number (the forecaster's own chance of this, stated with the estimate: 70%); the middle value lies beyond the limit too.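

No new step can be read, since compound 1 and compound 3 both give only a limit of the assay and not a number: the limit of > 36600 nM in this assay, at which 3 of the 3 values shown sit.

The compounds shown leave open how much of any of them is needed for the effect in this assay, and whether replacing (4-methoxyphenyl)amino with 3-bromophenyl changes that amount at all.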